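Bromophenyl substitution pattern in a sulfonyl enone series

The source may hold more compounds than are shown below. What is called first, only, known or untested is meant among the compounds shown, and "the series" means these compounds.

Compound 2 `Cc1ccc(CS(=O)(=O)/C(=C/c2ccc(Br)cc2)C(=O)c2ccc(Cl)cc2)cc1` in a functional assay on DU-145 cells (Homo sapiens) for inhibition, read by trypan blue exclusion, with a stated time of 96 h (on this read-out lower numbers stand for stronger inhibition of growth and higher numbers for weaker inhibition of growth), gives 25000 nM. Compound 3 `COc1cc(OC)c(/C=C(\C(=O)c2ccc(Br)cc2)S(=O)(=O)Cc2ccc(Cl)cc2)c(OC)c1` in this assay gives 25000 nM, level with compound 2 at the digits shown and within the scatter, and these two together hold the highest numbers of the three. Compound 1 `O=C(/C(=C\c1ccc([N+](=O)[O-])c(O)c1)SCc1ccc(Br)cc1)c1ccc([N+](=O)[O-])c(Cl)c1` in this assay gives 1000 nM, a much lower number, beyond the scatter. Among the measured compounds shown here, no pair among the measured compounds differs in only one place, so no measured step guides the next change. Compound 4 `Cc1ccc(CS(=O)(=O)/C(=C/c2ccccc2Br)C(=O)c2ccc(Cl)cc2)cc1` differs from compound 2 as follows: 2-bromophenyl in place of 4-bromophenyl on a double-bonded chain carbon bound to a double-bonded chain carbon. For the measured compounds named here, with no measured step of this kind, the expected step is no change at the digits printed from compound 2 to compound 4 (within the scatter), none beyond the scatter. Compound 4 is therefore estimated at 25000 nM, within a range from 8000 nM to 80000 nM.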

Compound 4, concentration for 50% growth inhibition: 25000 nM
The estimate for compound 4 equals the measured number at the digits printed; low and high end bracket the measured number.
By their numbers in this assay, from the lowest: compound 1; then compounds 2, 3 and 4 (each within the scatter of the next).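

In this assay the step at this place, on a double-bonded chain carbon bound to a double-bonded chain carbon, reads no change at the digits printed from compound 2 to compound 4 (within the scatter). Among the compounds shown here, this is the first measured step, and it shows that 2-bromophenyl in place of 4-bromophenyl does not separate the pair on this core. Nothing available bears on why the two read alike.

Going by these compounds, whether an amine or a carboxylic acid in place of the bromine would move the number stays open. So does whether this change would read the same on the core of compound 1, at 1000 nM.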